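A few compounds are considered here, and "the series" means these few. Any claim that something is new, unique, unknown or untested is made for them only; others in the source may bear on it.

Measured so far:
compound 1 `CC1(C)[C@H]2CC[C@]1(C)N(Cc1cn(-c3ccc(Cl)cc3)nn1)C(=O)C2` — 440 nM
compound 2 `COc1ccc(-n2cc(CN3C(=O)C[C@@H]4CC[C@@]3(C)C4(C)C)nn2)cc1` — 330 nM

In a functional assay on PANC-1 cells (Homo sapiens) for inhibition, read by MTT assay, with a stated time of 24 h (on this read-out lower numbers stand for stronger inhibition and higher numbers for weaker inhibition), compound 1 gives 440 nM, the higher of the two numbers recorded. Compound 2 gives 330 nM, and the step of a 1.3-fold lower number from compound 1 to compound 2 (0.12 log units; within the scatter) lies within the scatter. Compound 3 `CC1(C)[C@H]2CC[C@]1(C)N(Cc1cn(-c3ccc(F)cc3)nn1)C(=O)C2` differs from compound 1 by fluoro in place of chloro on an aromatic carbon. For the measured compounds named here, the only measured step that bears on it, an exchange of the same chloro on an aromatic carbon, moved the number little, so the step of a 1.1-fold higher number from compound 1 to compound 3 (0.06 log units; within the scatter) is expected to stay within the scatter. Compound 3 is therefore estimated at 500 nM, with a range from 250 nM to 1000 nM.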

Compound 3, half-maximal inhibitory concentration: 110 nM
The estimate for compound 3 lay 4.5-fold (0.66 log units) above the measured number; measured number below the stated range.
By their numbers in this assay, from the lowest: compound 3; then compounds 2 and 1 (each within the scatter of the next).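

In this assay the change from 4-chlorophenyl to 4-fluorophenyl gives a 4.0-fold lower number from compound 1 to compound 3 (0.60 log units; beyond the scatter) and the exchange of methoxy for fluoro gives a 3.0-fold lower number from compound 2 to compound 3 (0.48 log units; beyond the scatter) on the same aromatic carbon. This place, para to a large group, therefore responds to the group it carries, which the exchange of chloro for methoxy alone had not shown. No measurement at hand gives a reason for this difference. Open, going by these compounds, is how the plain phenyl ring, without any group at this place, would compare, and whether a nitrile, an amine or a trifluoromethyl group there would follow fluoro or chloro.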